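Aminopyridine in place of difluorophenyl on a thiazole acid core

A few compounds are considered here, and "the series" means these few. Any claim that something is new, unique, unknown or untested is made for them only; others in the source may bear on it.

Measured in an in vitro assay on HEK385-7 cells for displacement of a labelled ligand from prostaglandin D2 receptor 2 (Homo sapiens); a lower number here means a stronger inhibitor, a higher number a weaker inhibitor:
compound 1, `O=C(O)Cc1sc(C2COc3ccccc3O2)nc1-c1ccc(Cl)cc1`, gives 500 nM
compound 2, `O=C(O)Cc1sc(C(c2ccccc2)c2ccccc2)nc1-c1ccc(F)c(F)c1`, gives 4.1 nM
compound 3, `O=C(O)Cc1sc(C(c2ccc(F)cc2)c2ccc(F)cc2)nc1-c1cc(F)cc(F)c1`, gives 35 nM

Among these three numbers, compound 3 stands second highest in this assay. Its nearest neighbour is compound 2, whose lower number lies beyond the scatter; furthest is compound 1, whose higher number also lies beyond the scatter.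

Compound 4, `Cc1cc(-c2nc(C(c3ccc(F)cc3)c3ccc(F)cc3)sc2CC(=O)O)cnc1N`, has not been measured. It differs from compound 3 in one place: 6-amino-5-methylpyridin-3-yl in place of 3,5-difluorophenyl on an aromatic carbon. Going by the values given here, no measured pair shows this kind of change, so the direction is open. The step of a 1.7-fold higher number from compound 3 to compound 4 (0.23 log units; within the scatter) is expected to stay near the scatter, leaning slightly toward a higher number. Compound 4 is therefore estimated at 60 nM, with a range from 15 nM to 250 nM.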

Compound 4, half-maximal inhibitory concentration: 880 nM
The estimate for compound 4 lay 15-fold (1.17 log units) below the measured number; the measured number lies above the stated range.
By their numbers in this assay, from the lowest: compound 2; then compound 3; then compounds 1 and 4 (each within the scatter of the next).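

In this assay, 6-amino-5-methylpyridin-3-yl in place of 3,5-difluorophenyl gives a 25-fold higher number from compound 3 to compound 4 (1.40 log units; beyond the scatter), so this aromatic carbon of the shared core does not tolerate every six-membered aromatic ring equally. The heavy-atom count stays the same, while hydrogen-bond donor and acceptor atoms enter, so ring size and heavy-atom count alone do not set the number. No measurement here explains this change. The ring nitrogen, amine and methyl enter together, leaving open which of them matters. A plain pyridin-3-yl group or a 4-aminophenyl group could help separate them.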